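A few compounds are considered here, and "the series" means these few. Any claim that something is new, unique, unknown or untested is made for them only; others in the source may bear on it.

Compound 1 `O=C(COc1ccc2c(=O)ccoc2c1)Nc1cccc(NC(=O)c2ccccc2)c1`: 120 nM
Compound 2 `CCOc1ccc(C(=O)Nc2cccc(NC(=O)COc3ccc4c(=O)ccoc4c3)c2)cc1`: 17 nM
Compound 3 `O=C(COc1ccc2c(=O)ccoc2c1)Nc1cccc(NC(=O)c2ccc([N+](=O)[O-])cc2)c1`: 67 nM

All three were tested in an assay on isolated protein for inhibition of Rho-associated protein kinase 1 (Homo sapiens), read by scintillation counting, radiometric assay and 33P incorporation, with a stated time of 40 min, in the presence of a further agent that is not named here; on this read-out lower numbers stand for stronger inhibition and higher numbers for weaker inhibition. Compound 3 stands at the second highest of the three numbers: the step of a 1.8-fold lower number from compound 1 to compound 3 (0.25 log units; within the scatter) leaves it within the scatter of compound 1, while the step of a 3.9-fold higher number from compound 2 to compound 3 (0.60 log units; beyond the scatter) places it beyond the scatter of compound 2.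

Compound 4 `O=C(COc1ccc2c(=O)ccoc2c1)Nc1cccc(NC(=O)c2cccc([N+](=O)[O-])c2)c1` differs from compound 3 by 3-nitrophenyl in place of 4-nitrophenyl on a carbonyl carbon. Going by the values given here, no measured step moves a group to another position on that ring; the steps of a 1.8-fold lower number from compound 1 to compound 3 (0.25 log units; within the scatter) and a 3.9-fold higher number from compound 2 to compound 3 (0.60 log units; beyond the scatter) only swap what sits there, and only the ethoxy change exceeded the scatter. A step beyond the scatter is therefore not expected, and the expected step of a 1.1-fold higher number from compound 3 to compound 4 (0.05 log units; within the scatter) is small. Compound 4 is estimated at 75 nM, with a range from 25 nM to 220 nM.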

Compound 4, half-maximal inhibitory concentration: 528 nM
Beside the measured number, compound 4's estimate is 7.0-fold (0.85 log units) below it; measured number outside the range, above it.
By their numbers in this assay, from the lowest: compound 2; then compounds 3 and 1 (each within the scatter of the next); then compound 4.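

The same atoms give different results depending on where the nitro group sits: going from 4-nitrophenyl to 3-nitrophenyl gives a 7.9-fold higher number from compound 3 to compound 4 (0.90 log units; beyond the scatter). Placing the nitro group this way on the plain benzoyl ring of the core also gives a step beyond the scatter, a 4.4-fold higher number from compound 1 to compound 4 (0.64 log units; beyond the scatter), and the distance from the best 4-substituted ring widens to a 31-fold higher number from compound 2 to compound 4 (1.49 log units; beyond the scatter). No measurement here accounts for this sensitivity to position.

Still open, from the compounds shown here alone, is whether the loss follows the nitro group or the ring placement itself. A 3-ethoxyphenyl group would help separate the two, while an amine or a carboxylic acid there would show how different groups behave.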